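A few compounds are considered here, and "the series" means these few. Any claim that something is new, unique, unknown or untested is made for them only; others in the source may bear on it.

Compound 1, `CCOc1ccc(NC(=O)Nc2cc(C(C)(C)C)nn2-c2ccccc2)cc1`, in an assay on isolated protein for inhibition of STE20-like serine/threonine-protein kinase (Homo sapiens), read by thermal shift assay, tested at 10 uM (on this read-out higher numbers stand for stronger stabilisation of the target against heat and lower numbers for weaker stabilisation of the target), gives 1.1 degrees C. Compound 2, `CC(C)(C)c1cc(NC(=O)Nc2cc(C(F)(F)F)cc(C(F)(F)F)c2)n(-c2ccccc2)n1`, gives 0 degrees C in this assay. Among the measured compounds shown here, of the two numbers so far, compound 1 stands highest, and the gap down to compound 2 lies beyond the usual scatter. Compound 2 differs from compound 1 in more than one place, so its lower reading cannot be tied to any single change.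

Compound 3, `Cc1ccc(F)cc1NC(=O)Nc1cc(C(C)(C)C)nn1-c1ccccc1`, is not yet measured. It differs from compound 1 in one place: 5-fluoro-2-methylphenyl in place of 4-ethoxyphenyl on an amide-type nitrogen. The group that leaves carries one hydrogen-bond acceptor; the group that enters carries none. For the measured compounds named here, no step between measured compounds covers this kind of exchange, so the expectation rests only on the two readings above.

The step from compound 1 to compound 3 in this assay is expected to be small and downward, with the estimate a number 0.60 degrees C lower from compound 1 to compound 3 (within the scatter) not beyond the scatter. Compound 3 is expected to give about 0.5 degrees C, with a range from -0.5 degrees C to 1.5 degrees C.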

Compound 3, shift of the target's melting temperature: 6 degrees C
Compound 3: middle estimate off by 5.5 degrees C, on the low side; the whole stated range lies below it.
By their numbers in this assay, from the lowest: compound 2; then compound 1; then compound 3.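

On the amide-type nitrogen whose other neighbour is the carbonyl carbon, the aryl group proves a sensitive place in this assay: 5-fluoro-2-methylphenyl in place of 4-ethoxyphenyl gives a number 4.9 degrees C higher from compound 1 to compound 3 (beyond the scatter) and so a large step, with the rest of the structure unchanged. Among the compounds shown here, this is the first change that can be tied to a single place, which compound 2 could not provide, and it shows that exchanging this group alone can move the reading well beyond the scatter. Nothing shown gives a reason for the size of this step, so it stands as an observation only.

The exchange alters several things at once: the 4-ethoxyphenyl group carries a hydrogen-bond acceptor and the entering group carries none. The data do not separate the fluorine, the methyl and the loss of the ethoxy group within this step. A phenyl ring carrying only the fluorine or only the methyl would separate these parts, and a dimethylamino group on the same ring would test whether this place tolerates an amine.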